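Swapping the amine substituent for a pyridin-2-yl group

The compounds below may be only part of what the source reports. "The series", "measured", "known", "first", "only" and "open" are said of these compounds alone.

Measured compounds:
compound 1, `CN(CC1CCN(CCCc2c[nH]c3ccc(-n4cnnc4)cc23)CC1)C(=O)Nc1ccccc1`: 5.9 nM
compound 2, `C[C@@H](NCC1CCN(CCCc2c[nH]c3ccc(-n4cnnc4)cc23)CC1)c1ccccc1`: 1.4 nM
compound 3, `CC(=O)Nc1ccc([C@@H](C)NCC2CCN(CCCc3c[nH]c4ccc(-n5cnnc5)cc34)CC2)cc1`: 1.5 nM

All three share one core and differ only in what sits on the nitrogen of the side chain. In an assay on CHO cells for displacement of a labelled ligand from 5-hydroxytryptamine receptor 1D (Homo sapiens) (a lower number here means a stronger inhibitor, a higher number a weaker inhibitor), compound 3 gives 1.5 nM, the second highest of the three numbers; the nearest step is a 1.1-fold higher number from compound 2 to compound 3 (0.03 log units; within the scatter), so the acetamido group neither helps nor hurts, while compound 1 sits further off, a 4.2-fold lower number from compound 1 to compound 2 (0.62 log units; beyond the scatter).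

Compound 4, `c1ccc(NCC2CCN(CCCc3c[nH]c4ccc(-n5cnnc5)cc34)CC2)nc1`, has not yet been measured. The change from compound 3 is pyridin-2-yl in place of 1-(4-acetamidophenyl)ethyl on an amine nitrogen. Within the data shown here, the only step that bears on such a change at the amine nitrogen is the one from compound 1 to compound 2, a modest one, whereas the step from compound 2 to compound 3 shows that the aromatic substituent hardly matters. Compound 4 is therefore expected to give a somewhat higher number in this assay, a 5.3-fold higher number from compound 3 to compound 4 (0.73 log units; beyond the scatter), since the nitrogen is no longer carried on a chain carbon as in compound 2 and compound 3. The estimate for compound 4 is 8 nM, with a range from 2.5 nM to 25 nM.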

Compound 4, half-maximal inhibitory concentration: 1.7 nM
For compound 4 the middle estimate is 4.7-fold (0.67 log units) above the measured one; the measured number lies below the stated range.
By their numbers in this assay, from the lowest: compounds 2, 3 and 4 (each within the scatter of the next); then compound 1.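

In this assay, the amine nitrogen tolerates a far smaller group: pyridin-2-yl, with 6 heavy atoms and no defined stereocentre, replaces 1-(4-acetamidophenyl)ethyl, with 12 heavy atoms and one defined stereocentre, and the result is (a 1.1-fold higher number from compound 3 to compound 4 (0.05 log units; within the scatter)). The comparison with 1-phenylethyl reads the same (a 1.2-fold higher number from compound 2 to compound 4 (0.08 log units; within the scatter)), while compound 4 shares with compound 2 and compound 3 a clear separation from compound 1 (a 3.5-fold lower number from compound 1 to compound 4 (0.54 log units; beyond the scatter)). Nothing available explains why these different groups give such similar numbers.

As far as these compounds go, whether a pyridin-3-yl, a pyrimidin-2-yl or a plain phenyl group on this amine nitrogen would match pyridin-2-yl remains open. Also open, from the compounds shown here alone, is how much of the step from compound 1 belongs to the methyl on its nitrogen and how much to the phenylcarbamoyl group.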